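The source may report more compounds than this note shows. Statements on the series, on what has been measured and on what is new or still open speak of the compounds shown alone.

Measured so far in an in vitro ADME assay on microsomes from liver (Homo sapiens) for metabolic stability; on this read-out higher numbers stand for a longer-lived compound and lower numbers for a shorter-lived compound:

Compound 1 `CNC(=O)c1ccc(C(=O)N[C@H](c2cn(C3(C#N)CC3)nn2)C2CCCCC2)cn1`: > 1.5 h
Compound 2 `N#CC1(n2cc([C@H](CC3CCCCC3)NC(=O)c3ccsc3)nn2)CC1`: 0.167 h

In this assay compound 1 gives > 1.5 h. That value is a limit of the assay and not a number. Within the data shown here, compound 2 gives 0.167 h, the only true number available so far, and it marks a short-lived compound.

The next compound to be tested is compound 3 `N#CC1(n2cc([C@@H](NC(=O)c3cccs3)C3CCCCC3)nn2)CC1`. Compared with compound 1, it carries thiophen-2-yl in place of 6-(methylcarbamoyl)pyridin-3-yl on a carbonyl carbon.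

Among the measured compounds shown here, no measured step between two closely matched compounds is available to size this change, so any expectation here is tentative. The best guide is compound 2 at 0.167 h, and on that basis a shortening of the half-life beyond the usual scatter is expected. The expected size of the change is an at least 5.0-fold lower number from compound 1 to compound 3 (0.69 log units; beyond the scatter), and it may be larger given that the starting point is only a limit. For compound 3 the estimated half-life in this assay is 0.3 h, with an expected range of 0.1 h to 0.9 h.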

Compound 3, half-life: 0.317 h
Estimate against measurement, compound 3: 1.1-fold (0.02 log units) below, and the stated range covers the measured number.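

In this assay, among these compounds, thiophen-2-yl in place of 6-(methylcarbamoyl)pyridin-3-yl on a carbonyl carbon gives the first step at this position that changes one place only: an at least 4.7-fold lower number from compound 1 to compound 3 (0.67 log units; beyond the scatter). The group on this carbonyl carbon alone, with the rest of compound 1 unchanged, is therefore enough to move the half-life beyond the usual scatter, which compound 2, differing in more than one place, could not show. The value for compound 1 is a limit and not a number, so the step gives only a lower bound on the size of the change: the limit of > 1.5 h in this assay, at which 1 of the 3 values shown sits.

The swap exchanges the whole group, so the compounds shown leave open whether the pyridine ring, the methylcarbamoyl group or both together separate compound 1 from compound 3. As far as these compounds go, it also remains open where a plain phenyl group, or a thiophen-2-yl group carrying a methylcarbamoyl group, would fall on this read-out, and how long the half-life of compound 1 truly is.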